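This account rests on a few compounds, and the source may have more. Where it says the series, first, only, none or still open, it means among the compounds named here.

Compound 1 `COc1ccc(Cc2nnc(NC(=O)/C(C#N)=C/c3ccccc3OS(=O)(=O)c3ccccc3[N+](=O)[O-])s2)cc1` gives 18%
Compound 2 `COc1ccc(S(=O)(=O)Oc2ccccc2/C=C(\C#N)C(=O)Nc2nnc(Cc3ccccc3)s2)cc1` gives 23%

In an ADME assay on HEK-293T cells (Homo sapiens) for inhibition, read by CCK-8 assay, with a stated time of 48 h, tested at 20 uM (on this read-out lower numbers stand for less inhibition of growth and higher numbers for more inhibition of growth at the one concentration tested), compound 2 gives 23% and lies within the usual scatter of compound 1. Compound 3 `N#C/C(=C\c1ccccc1OS(=O)(=O)c1ccccc1[N+](=O)[O-])C(=O)Nc1nnc(Cc2ccccc2)s1` differs from compound 2 by one change: 2-nitrophenyl in place of 4-methoxyphenyl on a sulfonyl sulfur that is, 2-nitrophenyl in place of 4-methoxyphenyl on a sulfonyl sulfur. For the measured compounds named here, no measured pair shows this change alone. Going by the values given here, the only guides are compound 1 at 18% and compound 2 at 23% so no step beyond the scatter is expected in this assay in either direction. The estimated a number 3 percentage points lower from compound 2 to compound 3 (within the scatter) is small. Compound 3 is expected to give 20% with an estimated range of 8% to 33% for the coming measurement.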

Compound 3, percent growth inhibition at one concentration: 10%
Beside the measured number, compound 3's estimate is 10 percentage points above it; the range from low to high includes it.
By their numbers in this assay, from the lowest: compounds 3, 1 and 2 (each within the scatter of the next, the first and the last beyond it).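

In this assay, for the compounds shown here, the group on a sulfonyl sulfur can shift the read-out: 2-nitrophenyl in place of 4-methoxyphenyl gives a number 13 percentage points lower from compound 2 to compound 3 (beyond the scatter), the only step here beyond the usual scatter. Hydrogen in place of methoxy on an aromatic carbon gives a number 8 percentage points lower from compound 1 to compound 3 (within the scatter) and so cannot be told apart from that scatter. Nothing available explains either step. Still open, on these data alone, is how a simple methyl group or an unsubstituted phenyl on the sulfonyl sulfur would read. As far as these compounds go, whether an amine on that aromatic ring would move the number also remains open.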